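This account rests on a few compounds, and the source may have more. Where it says the series, first, only, none or still open, it means among the compounds named here.

Compound 2 `Cc1cc(OCc2cn(Cc3ccc([N+](=O)[O-])cc3)nn2)ccc1Cl` was examined in an ADME assay on A549 cells (Homo sapiens) for inhibition, read by MTT assay, with a stated time of 48 h (a lower number here means a stronger inhibitor of growth, a higher number a weaker inhibitor of growth), where compound 2 gives only the limit > 100 ug/mL and no number. Compound 1 `Clc1ccc(Cn2cc(COc3ccc(Cl)cc3)nn2)cc1` likewise reaches only the limit > 100 ug/mL in this assay. Both measured values thus sit at the limit of > 100 ug/mL in this assay, at which 2 of the 2 values shown sit, so compound 2 stands where compound 1 stands, with no number below the limit. Compound 3 `Cc1cc(OCc2cn(Cc3ccc(Cl)cc3)nn2)ccc1Cl` differs from compound 2 by chloro in place of nitro on an aromatic carbon. Compound 1 already carries a chloro and gives only the limit > 100 ug/mL. The expected step that the limit leaves unreadable from compound 2 to compound 3 is therefore none beyond the scatter. Compound 3 is expected at 150 ug/mL, between 50 ug/mL and 500 ug/mL, most likely again only a limit.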

Compound 3, concentration for 50% growth inhibition: > 100 ug/mL
Compound 3: only a limit was reported; the forecaster's own chance of this, stated with the estimate: 85%; the middle value does not contradict the limit.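

Going by these compounds alone, compound 3, like compound 1 and compound 2, gives only a limit in this assay, so no step among them can be read: the limit of > 100 ug/mL in this assay, at which 3 of the 3 values shown sit. The compounds shown leave open whether chloro in place of nitro, or methyl in place of hydrogen, changes growth inhibition at all.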